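The source may hold more compounds than are shown below. What is called first, only, known or untested is meant among the compounds shown, and "the series" means these compounds.

Measured in a functional assay on A549 cells (Homo sapiens) for inhibition, read by MTT assay, with a stated time of 72 h; a lower number here means a stronger inhibitor, a higher number a weaker inhibitor:
- Compound 1 `CC1=NN(c2ccccc2)C(=O)[C@@]12C(=O)C=CC[C@@H]2c1ccc(C)cc1`: 6570 nM
- Compound 2 `COc1ccccc1[C@@H]1CC=CC(=O)[C@]12C(=O)N(c1ccccc1)N=C2C`: 3960 nM
- Compound 3 `COc1ccccc1[C@H]1CC=CC(=O)[C@@]12C(=O)N(c1ccccc1)N=C2C`: 18700 nM

Compound 3, at 18700 nM, has the highest number of the three, which makes it the weakest inhibitor here. Compound 4 `CC1=NN(c2ccccc2)C(=O)[C@@]12C(=O)C=CC[C@@H]2c1ccccc1` has hydrogen in place of methoxy on an aromatic carbon, turning 2-methoxyphenyl into phenyl (hydrogen in place of methoxy on an aromatic carbon). The most relevant measured change is a 2.8-fold higher number from compound 1 to compound 3 (0.45 log units; beyond the scatter), where 2-methoxyphenyl replaced 4-methylphenyl. The larger 4.7-fold higher number from compound 2 to compound 3 (0.67 log units; beyond the scatter) involves mirror images, so it says little about this swap. Removing the methoxy should therefore move the number back towards that of compound 1. The expected change is a 2.3-fold lower number from compound 3 to compound 4 (0.37 log units; beyond the scatter), a modest step to a lower number. The estimate for compound 4 is 8000 nM, with an expected range of 3000 nM to 18000 nM.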

Compound 4, half-maximal inhibitory concentration: 7770 nM
The estimate for compound 4 lay 1.0-fold (0.01 log units) above the measured number; the measured number falls inside the stated range.
By their numbers in this assay, from the lowest: compounds 2, 1 and 4 (each within the scatter of the next); then compound 3.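

Removing the methoxy gives a 2.4-fold lower number from compound 3 to compound 4 (0.38 log units; beyond the scatter), so in compound 3 this group goes with a weaker inhibitor, and the plain phenyl ring does not share that penalty. Swapping the methyl of the 4-methylphenyl group for hydrogen gives a 1.2-fold higher number from compound 1 to compound 4 (0.07 log units; within the scatter), so that methyl makes no readable difference here. As far as these compounds go, how the mirror image of compound 4 would compare stays open, and configuration cannot be set aside: the fact that compounds 2 and 3 differ only in the configuration as drawn. From the compounds shown here alone, whether an amine or a carboxylic acid on this aromatic ring would shift the number also remains open.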